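The compounds below may be only part of what the source reports. "The series", "measured", "known", "first", "only" and "open" are said of these compounds alone.

Compound 2 `CC1=C(C(=O)Nc2ccc([N+](=O)[O-])cc2)C(c2cccc([N+](=O)[O-])c2)N=C(SCc2ccccc2Cl)N1` gives 11.3% in a functional assay on the whole organism (artery, strain albino) with Rattus norvegicus as the target, with a stated time of 720 min, at a dose of 10 mg/kg by the oral route (a higher number here means more inhibition at the dose given (going by the name of the read-out), a lower number less inhibition), the lower of the two numbers measured, though compound 1 `CC1=C(C(=O)Nc2ccc([N+](=O)[O-])cc2)C(c2cccc([N+](=O)[O-])c2)N=C(SCc2ccccc2)N1` gives 17.5% and the step of a number 6.2 percentage points lower from compound 1 to compound 2 (within the scatter) lies within the scatter. Compound 3 `CC1=C(C(=O)Nc2ccc([N+](=O)[O-])cc2)C(c2cccc([N+](=O)[O-])c2)N=C(SCc2cccc(Cl)c2)N1` differs from compound 2 by 3-chlorophenyl in place of 2-chlorophenyl on a saturated chain carbon bound to a sulfur. Going by the values given here, the only measured step touching this part of the molecule is the one from compound 1 to compound 2, and it stayed within the scatter. Among the compounds with values here, no measured step moves a chloro from one ring position to another. The expected step is therefore a number 2.7 percentage points higher from compound 2 to compound 3 (within the scatter), nothing beyond the scatter. Compound 3 is estimated at 14%, between 4% and 26%.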

Compound 3, a percentage reported as inhibition, in the whole organism at one dose (the size of the read-out at that dose, not a potency): 12.9%
Beside the measured number, compound 3's estimate is 1.1 percentage points above it; measured number inside the range.
By their numbers in this assay, from the lowest: compounds 2, 3 and 1 (each within the scatter of the next).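

Moving the chloro, 3-chlorophenyl in place of 2-chlorophenyl on a saturated chain carbon bound to a sulfur, gives in this assay a number 1.6 percentage points higher from compound 2 to compound 3 (within the scatter) and so does not separate these two ring positions. With the 3-chlorophenyl group, chloro in place of hydrogen gives a number 4.6 percentage points lower from compound 1 to compound 3 (within the scatter) and so, like the 2-chlorophenyl group, does not separate from compound 1. On these data alone, whether a methoxy group or an amine on this ring, or a longer chain in place of the benzyl, would move the number beyond the scatter stays open. No supporting data bear on these results.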